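A few compounds are considered here, and "the series" means these few. Any claim that something is new, unique, unknown or untested is made for them only; others in the source may bear on it.

Three compounds share one core and differ only in the group on a carbonyl carbon. Compound 1 `COCCOC(=O)c1cc(N)c(Nc2ccc(C#N)cc2)cc1Oc1c(C)cc(/C=C/C#N)cc1C` carries a 2-methoxyethoxy group there, compound 2 `Cc1cc(/C=C/C#N)cc(C)c1Oc1cc(Nc2ccc(C#N)cc2)c(N)cc1C(=O)NCCC(F)F` a (3,3-difluoropropyl)amino group, and compound 3 `CCNC(=O)c1cc(N)c(Nc2ccc(C#N)cc2)cc1Oc1c(C)cc(/C=C/C#N)cc1C` an ethylamino group. In a physicochemical assay for solubility, read by HPLC, with a stated time of 4 h, at pH 2 (a lower number here means a less soluble compound, a higher number a more soluble compound), compound 1 gives 1.64 ug/mL, compound 2 gives 57.6 ug/mL, and compound 3 gives 69.4 ug/mL. Compound 2 stands second highest of the three: its number sits close to that of compound 3, since a 1.2-fold higher number from compound 2 to compound 3 (0.08 log units; within the scatter), and far from that of compound 1, since a 35-fold higher number from compound 1 to compound 2 (1.55 log units; beyond the scatter).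

Compound 4 `Cc1cc(/C=C/C#N)cc(C)c1Oc1cc(Nc2ccc(C#N)cc2)c(N)cc1C(=O)N1CC1` is not yet measured. It differs from compound 2 in one place: aziridin-1-yl in place of (3,3-difluoropropyl)amino on a carbonyl carbon. The measured steps give only indirect guidance. The steps of a 35-fold higher number from compound 1 to compound 2 (1.55 log units; beyond the scatter) and a 42-fold higher number from compound 1 to compound 3 (1.63 log units; beyond the scatter) show that moving from the 2-methoxyethoxy group to either amino group changed this assay a great deal, while a 1.2-fold higher number from compound 2 to compound 3 (0.08 log units; within the scatter) shows that the tail of the amino group mattered little. Among the measured compounds shown here, no measured step exchanges the hydrogen-bond donor for a three-membered ring, so the expectation is loose. A step of moderate size downward is expected, a 2.3-fold lower number from compound 2 to compound 4 (0.36 log units; beyond the scatter), and compound 4 is estimated at 25 ug/mL, between 6 ug/mL and 100 ug/mL.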

Compound 4, solubility: 94.2 ug/mL
The estimate for compound 4 lay 3.8-fold (0.58 log units) below the measured number; low and high end bracket the measured number.
By their numbers in this assay, from the lowest: compound 1; then compounds 2, 3 and 4 (each within the scatter of the next).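

In this assay, putting aziridin-1-yl in place of (3,3-difluoropropyl)amino gives a 1.6-fold higher number from compound 2 to compound 4 (0.21 log units; within the scatter), and putting it in place of ethylamino gives a 1.4-fold higher number from compound 3 to compound 4 (0.13 log units; within the scatter). Every amide measured earlier kept one hydrogen-bond donor in this group, whereas aziridin-1-yl has none and brings a three-membered ring, so on this carbonyl carbon neither the absence of the amide hydrogen nor the ring takes the number beyond the usual scatter. The wide gap from the 2-methoxyethoxy compound also remains, at a 57-fold higher number from compound 1 to compound 4 (1.76 log units; beyond the scatter), so that gap does not depend on a hydrogen on the nitrogen, though nothing measured here bears on why these nitrogen groups read alike.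

Still open, from the compounds shown here alone, is whether a larger ring on the same carbonyl carbon, such as piperidin-1-yl or morpholin-4-yl, or a chain ending in a dimethylamino group, would stay within the scatter of compound 2, compound 3 and compound 4. A plain dimethylamino group on the carbonyl carbon would also separate the missing amide hydrogen from the ring, two features that compound 4 changes together.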